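This account rests on a few compounds, and the source may have more. Where it says the series, first, only, none or still open, it means among the compounds named here.

For the measured compounds named here, in a physicochemical assay for lipophilicity, at pH 7.4 (a lower number here means a more polar compound, a higher number a more lipophilic compound), compound 1 (`O=c1[nH]c(OC2CCCCC2)nc2cnccc12`) gives 3.7 as the lower of the two numbers known so far. Compound 2 (`O=c1[nH]c(OCC2CCCCC2)nc2cnccc12`) gives 4.5 and the gap between them lies beyond the usual scatter of repeated measurements. The next compound to be measured is compound 3 (`O=c1[nH]c(Oc2cccnc2)nc2cnccc12`). It differs from compound 1 in one place, with pyridin-3-yl in place of cyclohexyl on an oxygen on an aromatic ring. The two rings have the same number of heavy atoms, but only the entering one is aromatic and holds a nitrogen. Going by the values given here, no pair of measured compounds shows this swap, so the expectation rests on the structural change alone and remains uncertain. A clear fall in this assay is expected, well beyond the scatter, with an estimated step of a number 1.70 log units lower from compound 1 to compound 3 (beyond the scatter) as its size. For compound 3 the expected value is 2 within an estimated range of 1.2 to 2.8 once it is measured.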

Compound 3, distribution coefficient: -0.2
Compound 3: the middle estimate sits 2.20 log units above what was measured, outside the stated range (below it).
By their numbers in this assay, from the lowest: compound 3; then compound 1; then compound 2.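

In this assay, the group on an oxygen on an aromatic ring can shift the read-out by a large amount: the change gives a number 3.90 log units lower from compound 1 to compound 3 (beyond the scatter). The leaving and entering groups have the same number of heavy atoms, so that count alone does not set the number at this place. What changes instead is that a non-aromatic ring of carbon only gives way to pyridin-3-yl, an aromatic ring with one nitrogen and one hydrogen-bond acceptor.

These compounds cannot show how much of the step goes with the aromatic ring and how much with its nitrogen; a phenyl group at this place would separate the two, and pyridin-4-yl would test where the nitrogen sits. No measurement at hand gives a reason for the size of this step.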